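The source may hold more compounds than are shown below. What is called first, only, known or untested is meant among the compounds shown, and "the series" means these compounds.

Working notes on the trimethoxyphenyl series in a functional assay on ONS-76 cells (Homo sapiens) for cytotoxicity, read by MTT assay, with a stated time of 72 h; a higher number here means a weaker inhibitor, a lower number a stronger inhibitor.

Compound 3 `COc1ccc(C(=O)N(C)c2cc(OC)c(OC)c(OC)c2)cc1` is an amide bearing a methyl on the amide nitrogen and a 4-methoxyphenyl on the carbonyl side. In this assay compound 3 gives >= 125000 nM, which is a limit of the assay and not a number. Compound 1 `COc1cc(N(C)C(=O)c2ccc(F)cc2)cc(OC)c1OC` carries the same core with the change (fluoro in place of methoxy on an aromatic carbon). In this assay compound 1 gives >= 125000 nM, again a limit rather than a number. The step that the two limits leave unreadable from compound 3 to compound 1 is therefore not readable, because both ends sit at the limit of >= 125000 nM in this assay, at which 2 of the 3 values shown sit.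

Compound 2 `COc1ccc(NC(=O)Nc2cc(OC)c(OC)c(OC)c2)cc1` is the urea of the set, with a 4-methoxyphenyl as the aryl group on the urea; the difference between its core and the core of compound 3 is not broken down here. In this assay, going by the values given here, compound 2 gives 12900 nM, the only full number among the three measured compounds.

Compound 4 `COc1cc(NC(=O)Nc2ccc(F)cc2)cc(OC)c1OC` is the urea counterpart carrying the change (fluoro in place of methoxy on an aromatic carbon), the same change as from compound 3 to compound 1, with the place described in identical words. The earlier instance of the change gives no readable size, so the expectation for compound 4 rests on compound 2 and its value 12900 nM alone, with a wide band around it. Compound 4 is expected near 16000 nM, between 5000 nM and 60000 nM. The implied step a 1.2-fold higher number from compound 2 to compound 4 (0.09 log units; within the scatter) is expected to fall within the usual scatter.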

Compound 4, half-maximal inhibitory concentration: 63300 nM
The estimate for compound 4 lay 4.0-fold (0.60 log units) below the measured number, outside the stated range (above it).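

In this assay, fluoro in place of methoxy on an aromatic carbon, which is 4-methoxyphenyl to 4-fluorophenyl when cut one bond further out, gives a 4.9-fold higher number from compound 2 to compound 4 (0.69 log units; beyond the scatter), a modest step towards a weaker inhibitor but one beyond the usual scatter. The same change on the core of compound 3 cannot be read, because compound 3 and compound 1 both give a limit of the assay and not a number: the limit of >= 125000 nM in this assay, at which 2 of the 4 values shown sit. This leaves a single readable instance of the change, which shows a loss on the core of compound 2 only and does not show that the step keeps its size, or even its direction, on another core; nor does it give any reason for the step.

The compounds shown leave open whether the step belongs to fluoro entering or to methoxy leaving, a question on which a plain phenyl, or a chloro, an amine or a carboxylic acid at the same place on the core of compound 2, would bear. They also leave open how large the change is on the core of compound 3, where neither end of the step is yet a number.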